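This account rests on a few compounds, and the source may have more. Where it says the series, first, only, none or still open, it means among the compounds named here.

Of the compounds shown here, two sharing the same core have been tested in a functional assay on PC-12 cells (Rattus norvegicus) for inhibition, read by sulforhodamine B assay; on this read-out higher numbers stand for weaker inhibition and lower numbers for stronger inhibition. Compound 1, `Cc1c(C)c2c(c(C)c1O)CCC(C)(COc1ccc(/C=C3/SC(=O)NC3=O)cc1)O2`, gives 5000 nM in this assay. Compound 2, `O=C1NC(=O)C(Cc2ccc(OCC3CCCCO3)cc2)S1`, reaches only the limit of this assay, giving > 100000 nM, so no number stands for it. Where compound 2 stands is known solely as a limit, (the limit of > 100000 nM in this assay, at which 1 of the 2 values shown sits), and its distance from compound 1 cannot be counted. Compound 3, `O=C1NC(=O)C(Cc2ccc(OCC3CCCCC3)cc2)S1`, differs from compound 2 at one place: cyclohexyl in place of oxan-2-yl on a saturated chain carbon bound to an oxygen on an aromatic ring. The oxan-2-yl ring with its one hetero atom gives way to a six-membered ring of carbon only, on a saturated chain carbon bound to an oxygen on an aromatic ring. Among the measured compounds shown here, no measured step of this kind exists to lean on. The expected step of a number no higher from compound 2 to compound 3 (the limit leaves the size open) is none beyond the usual scatter. Compound 3 is expected most likely to return only a limit as well, and is estimated at 100000 nM, with a range from 30000 nM to 300000 nM.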

Compound 3, half-maximal inhibitory concentration: 26000 nM
Compound 3: middle estimate off by 3.8-fold (0.59 log units), on the high side, outside the stated range (below it).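

In this assay, putting cyclohexyl in place of oxan-2-yl on a saturated chain carbon bound to an oxygen on an aromatic ring gives an at least 3.8-fold lower number from compound 2 to compound 3 (0.58 log units; beyond the scatter). Among the compounds shown here, this is the first step between compounds differing in one place, and it shows that exchanging the ring with one hetero atom for a six-membered ring of carbon only is enough to bring a number into reach of this read-out. For compound 2 the reading is a limit and not a number, so the step has a floor but no upper bound: the limit of > 100000 nM in this assay, at which 1 of the 3 values shown sits.

Going by these compounds, whether a phenyl ring, a piperidin-2-yl ring with its amine, or a longer chain at this place would lower the number further stays open. Compound 1 differs from compound 3 in more than one place, so what separates those two stays unassigned.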